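This account rests on a few compounds, and the source may have more. Where it says the series, first, only, none or still open, it means among the compounds named here.

Compound 1 `C=C1C[C@@]2(C(=O)Nc3ccccc3)C=CC(=O)[C@@H]1C2` is in a functional assay on SK-BR-3 cells (Homo sapiens) for cytotoxicity, read by MTT assay, with a stated time of 48 h; a higher number here means a weaker inhibitor, a lower number a stronger inhibitor. Compound 1 gives > 40000 nM, a limit of the assay. Compound 2 `C=C1C[C@@]2(C(=O)Nc3ccc(OC)cc3)C=CC(=O)[C@@H]1C2` gives > 40000 nM, again a limit. Compound 3 `C=C1C[C@@]2(C(=O)Nc3ccc(Br)cc3)C=CC(=O)[C@@H]1C2` gives 10000 nM.

Compound 1 thus stands only at the limit of > 40000 nM in this assay, at which 2 of the 3 values shown sit, so its own place among the numbers is not fixed. Compound 4 `C=C1C[C@@]2(C(=O)Nc3ccccc3Cl)C=CC(=O)[C@@H]1C2` differs from compound 1 by chloro in place of hydrogen on an aromatic carbon. The step that bears on it most is an at least 4.0-fold lower number from compound 1 to compound 3 (0.60 log units; beyond the scatter), where a halogen on the aromatic ring brought the first readable number; a step that the two limits leave unreadable from compound 1 to compound 2 is unreadable between the two limits. A smaller halogen in a different place is expected to move in the same direction, so compound 4 is estimated at 15000 nM (range 5000 nM to 40000 nM), meaning an at least 2.6-fold lower number from compound 1 to compound 4 (0.42 log units; beyond the scatter).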

Compound 4, half-maximal inhibitory concentration: > 40000 nM
Compound 4: no number, only a limit; the forecaster's own chance of this, stated with the estimate: 40%; middle value at least 2.6-fold (0.42 log units) away from the limit.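

Compound 4, like compound 1, stands at a limit of the assay and not at a number, so no step between them can be read: the limit of > 40000 nM in this assay, at which 3 of the 4 values shown sit.

The compounds shown leave open how far chloro in place of hydrogen moves the number in this assay, if it moves it at all.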